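Swapping the benzyl ether aryl group toward a dimethoxyphenyl

The source may hold more compounds than are shown below. What is called first, only, known or untested is meant among the compounds shown, and "the series" means these compounds.

Measured compounds:
- compound 1, `Cc1ccccc1COc1ccc(-c2cc(CN3CCN(Cc4ccc(C(F)(F)F)cc4)CC3)no2)cc1`: 6800 nM
- compound 2, `N#Cc1cccc(COc2ccc(-c3cc(CN4CCN(Cc5ccc(C(F)(F)F)cc5)CC4)no3)cc2)c1`: 10600 nM
- compound 3, `Fc1ccccc1COc1ccc(-c2cc(CN3CCN(Cc4ccc(C(F)(F)F)cc4)CC3)no2)cc1`: 3100 nM

All three share the same core and differ only in the aryl group attached to the saturated chain carbon bound to an oxygen on an aromatic ring. In a functional assay on Mahlavu cells (Homo sapiens) for antiproliferative activity, read by sulforhodamine B assay, with a stated time of 72 h (a higher number here means a weaker inhibitor, a lower number a stronger inhibitor), compound 3 has the lowest number of the three: a 2.2-fold lower number from compound 1 to compound 3 (0.34 log units; beyond the scatter) and a 3.4-fold lower number from compound 2 to compound 3 (0.53 log units; beyond the scatter) are both modest steps beyond the scatter, while a 1.6-fold higher number from compound 1 to compound 2 (0.19 log units; within the scatter) stays within it.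

Compound 4, `COc1cc(COc2ccc(-c3cc(CN4CCN(Cc5ccc(C(F)(F)F)cc5)CC4)no3)cc2)cc(OC)c1`, has not yet been measured. It differs from compound 3 by 3,5-dimethoxyphenyl in place of 2-fluorophenyl on a saturated chain carbon bound to an oxygen on an aromatic ring. The two measured steps at this position show that moving away from the 2-fluorophenyl group gives a modestly higher number, whether the other group is a 2-methylphenyl or a 3-cyanophenyl. Nothing measured here tells how a 3,5-dimethoxyphenyl behaves, so the expectation rests on that pattern alone. A modest rise is therefore expected: a 1.9-fold higher number from compound 3 to compound 4 (0.29 log units; within the scatter). Compound 4 is expected to give about 6000 nM in this assay, in a range from 2500 nM to 15000 nM.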

Compound 4, half-maximal inhibitory concentration: 4300 nM
Compound 4: middle estimate off by 1.4-fold (0.14 log units), on the high side, and the stated range covers the measured number.
By their numbers in this assay, from the lowest: compounds 3, 4, 1 and 2 (each within the scatter of the next, the first and the last beyond it).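

In this assay, the 3,5-dimethoxyphenyl group is larger than 2-fluorophenyl, with 10 heavy atoms against 7 and 2 hydrogen-bond acceptors against 0, yet the change stays within the scatter (a 1.4-fold higher number from compound 3 to compound 4 (0.14 log units; within the scatter)). The same holds against the 2-methylphenyl group (a 1.6-fold lower number from compound 1 to compound 4 (0.20 log units; within the scatter)), and only the comparison with the 3-cyanophenyl group goes beyond the scatter (a 2.5-fold lower number from compound 2 to compound 4 (0.39 log units; beyond the scatter)), so this position accepts a bulkier, doubly substituted aryl group and 2-fluorophenyl no longer stands apart from every other group. No measurement shown gives a reason for this.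

The compounds shown leave open whether both methoxy groups matter, since a phenyl group carrying only one is not among them. They also leave open how a phenyl group carrying an amine or a carboxylic acid would behave at this position.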